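Lengthening the Ester Chain: From Compound 3 to Compound 4

The source may hold more compounds than are shown below. What is called first, only, known or untested is meant among the compounds shown, and "the series" means these compounds.

Three measured compounds share one core and differ only in the chain of the ester. Compound 1 `CCCCCCCOC(=O)CCC(=O)N1CCN(CCCOc2cc3c(Nc4ccc(F)c(Cl)c4)ncnc3cc2OC)CC1` gives 79.9% in a functional assay on A549 cells (Homo sapiens) for cytotoxicity, read by MTT assay, with a stated time of 24 h, tested at 20 uM (a higher number here means a weaker effect of the compound at the concentration tested, a lower number a stronger effect), compound 2 `CCCCCCCCCCOC(=O)CCC(=O)N1CCN(CCCOc2cc3c(Nc4ccc(F)c(Cl)c4)ncnc3cc2OC)CC1` gives 88.2%, and compound 3 `CCCCCCCCCCCCCCCOC(=O)CCC(=O)N1CCN(CCCOc2cc3c(Nc4ccc(F)c(Cl)c4)ncnc3cc2OC)CC1` gives 91.2%. Compound 3 stands highest of these three numbers; the gap a number 3 percentage points higher from compound 2 to compound 3 (within the scatter) is small, while the gap a number 11.3 percentage points higher from compound 1 to compound 3 (beyond the scatter) is modest. Compound 4 `CCCCCCCCCCCCCCCCCCCOC(=O)CCC(=O)N1CCN(CCCOc2cc3c(Nc4ccc(F)c(Cl)c4)ncnc3cc2OC)CC1` carries butyl in place of hydrogen on a saturated chain carbon, ten or more bonds along the chain from an oxygen next to a carbonyl group. The step of a number 3 percentage points higher from compound 2 to compound 3 (within the scatter), the same kind of lengthening, bears most directly, and a number 8.3 percentage points higher from compound 1 to compound 2 (within the scatter) also stayed small. The expected change is therefore a number 0.8 percentage points higher from compound 3 to compound 4 (within the scatter), essentially none beyond the scatter. Compound 4 is estimated at 92%, between 84% and 99%.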

Compound 4, a percentage reported as activity, at one concentration (the size of the read-out at that concentration, not a potency): 94.8%
Beside the measured number, compound 4's estimate is 2.8 percentage points below it; the measured number falls inside the stated range.
By their numbers in this assay, from the lowest: compounds 1, 2, 3 and 4 (each within the scatter of the next, the first and the last beyond it).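

Adding butyl gives a number 3.6 percentage points higher from compound 3 to compound 4 (within the scatter) and adding nonyl gives a number 6.6 percentage points higher from compound 2 to compound 4 (within the scatter) in this assay, so even this further lengthening of an already long chain produces no change beyond the scatter. Only the wider dodecyl step gives a difference beyond the scatter, with a number 14.9 percentage points higher from compound 1 to compound 4 (beyond the scatter) as the result. No evidence is available to explain these numbers.

From the compounds shown here alone, whether a chain shorter than that of compound 1 would give a different reading remains open. So does the effect of a terminal amine or carboxylic acid on the chain.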